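This account rests on a few compounds, and the source may have more. Where it says the series, first, only, none or still open, it means among the compounds named here.

Measured in a functional assay on HeLa cells (Homo sapiens) for inhibition (on this read-out lower numbers stand for stronger inhibition and higher numbers for weaker inhibition), so far:
compound 1 `Oc1ccc(-c2cc(-c3cccc(F)c3)cc(-c3cccc(O)c3)n2)cc1` gives 14200 nM;
compound 2 `Oc1cccc(-c2cc(-c3cccc(OC(F)(F)F)c3)cc(-c3ccccc3O)n2)c1` gives 14900 nM;
compound 3 `Oc1cccc(-c2cc(-c3cccc(OC(F)(F)F)c3)cc(-c3cccc(O)c3)n2)c1` gives only the limit > 50000 nM.

Compound 3 thus sits at the limit of this assay and shows no number, at the limit of > 50000 nM in this assay, at which 1 of the 3 values shown sits. Among the measured compounds shown here, the one step measured within the set, an at least 3.3-fold higher number from compound 2 to compound 3 (0.52 log units; beyond the scatter), is the change to a 3-hydroxyphenyl group and runs to weaker inhibition. Compound 4 `Oc1ccc(-c2cc(-c3cccc(OC(F)(F)F)c3)cc(-c3cccc(O)c3)n2)cc1` carries the change (4-hydroxyphenyl in place of 3-hydroxyphenyl on an aromatic carbon), the 4-hydroxyphenyl arrangement that compound 1 also has with its fluorine-bearing ring. For the measured compounds named here, no measured step matches this change directly; compound 1 stands clearly within the numbered range of this assay, and compound 2 does as well. Compound 4 is therefore expected to return into the numbered range, estimated at 25000 nM (range 8000 nM to 80000 nM). This estimate means an expected step of an at least 2.0-fold lower number from compound 3 to compound 4 (0.30 log units; that floor lies within the scatter).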

Compound 4, half-maximal inhibitory concentration: 14100 nM
Compound 4: the middle estimate sits 1.8-fold (0.25 log units) above what was measured; the measured number falls inside the stated range.
By their numbers in this assay, from the lowest: compounds 4, 1 and 2 (each within the scatter of the next). At a limit, above all of these: compound 3.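

In this assay, the 3-hydroxyphenyl group next to the ring nitrogen is not interchangeable with its isomer, with an at least 3.5-fold lower number from compound 3 to compound 4 (0.54 log units; beyond the scatter). The 2-hydroxyphenyl and 4-hydroxyphenyl groups read alike at this position, with a 1.1-fold lower number from compound 2 to compound 4 (0.02 log units; within the scatter), and trifluoromethoxy and fluoro read alike on the other ring, with a 1.0-fold lower number from compound 1 to compound 4 (0.00 log units; within the scatter). Compound 3 stays at a limit, so its step gives only a floor: the limit of > 50000 nM in this assay, at which 1 of the 4 values shown sits.

On these data alone, whether the hydroxyl on this ring is needed at all remains open. So does how a methoxy group, an amine or a carboxylic acid would read in its place.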